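Fluoro for Nitro at Two Ring Positions

This account rests on a few compounds, and the source may have more. Where it says the series, first, only, none or still open, it means among the compounds named here.

Of the compounds shown here, three sharing one core have been tested in a toxicity assay on the whole organism with Rattus norvegicus as the target, at a dose of 200 mg/kg by the oral route; a lower number here means a weaker effect, a higher number a stronger effect of the compound at the dose given. Compound 1, `Fc1ccc(OCC2=NCCO2)cc1`, gives 40%. Compound 2, `O=[N+]([O-])c1ccccc1OCC1=NCCO1`, gives 55%, and compound 3, `O=[N+]([O-])c1ccc(OCC2=NCCO2)cc1`, gives 70%. Compound 2 and compound 3 are built from the same atoms joined differently; the difference between the two cores is not broken down here. Compound 3 and compound 1 differ in one place, (fluoro in place of nitro on an aromatic carbon), and that change gave a number 30 percentage points lower from compound 3 to compound 1 (beyond the scatter).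

Compound 4, `Fc1ccccc1OCC1=NCCO1`, has not yet been measured. It differs from compound 2 by fluoro in place of nitro on an aromatic carbon. Within the data shown here, this is the same kind of change as the one from compound 3 to compound 1, but not the same: in compound 1 the fluoro stands para to a group of 7 heavy atoms, while in compound 4 it stands ortho to a group of 7 heavy atoms. Among the measured compounds shown here, only one measured example of this swap exists, and it lies at the other position, so the expectation rests on that single step of a number 30 percentage points lower from compound 3 to compound 1 (beyond the scatter) carried over to compound 2. Compound 4 is therefore expected to move by a number 27 percentage points lower from compound 2 to compound 4 (beyond the scatter) in this assay. Compound 4 is estimated at 28%, with the range 10% to 45%.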

Compound 4, a percentage reported as activity, at one dose (the size of the read-out at that dose, not a potency): 60%
Estimate against measurement, compound 4: 32 percentage points below; measured number outside the range, above it.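

In this assay, putting fluoro in place of nitro on the ring of compound 2 gave a number 5 percentage points higher from compound 2 to compound 4 (within the scatter), so this swap produces no readable change on this core. Set beside the earlier example, the same swap clearly does not carry over from one core to the other with the same size: the same change on two cores in this assay, a number 30 percentage points lower (beyond the scatter) from compound 3 to compound 1 and a number 5 percentage points higher (within the scatter) from compound 2 to compound 4, 35 percentage points apart, beyond the scatter of two such steps. This shows that a step measured on one core is a poor guide to the other in this series, but it does not show what separates the two cases, since two examples cannot tell whether the place of the swap, here ortho to a group of 7 heavy atoms, decides the outcome or whether something else does.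

The compounds shown leave open how other groups would behave at the same ring carbon, for instance an amine or a carboxylic acid in place of the nitro. They also leave open what a longer chain linking the ring to the rest of the molecule would do to these numbers.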